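Chloro added to the urea aryl of compound 3

The source may hold more compounds than are shown below. What is called first, only, known or untested is meant among the compounds shown, and "the series" means these compounds.

Compound 3 `COc1cc(-c2nn(-c3cccc(NC(=O)Nc4cccc(C(F)(F)F)c4)c3)cc2-c2ccncc2)ccc1Cl` carries a methyl on the ring oxygen and a 3-(trifluoromethyl)phenyl on the urea nitrogen. In a functional assay on OVCAR-4 cells (Homo sapiens) for inhibition, read by sulforhodamine B assay, with a stated time of 48 h (on this read-out higher numbers stand for lower toxicity in this test and lower numbers for higher toxicity in this test), compound 3 gives > 50000 nM, which is a limit of the assay and not a number. Compound 1 `O=C(Nc1cccc(-n2cc(-c3ccncc3)c(-c3ccc(Cl)c(O)c3)n2)c1)Nc1cccc(C(F)(F)F)c1` has a hydrogen in place of that methyl. In this assay compound 1 gives > 32500 nM, again a limit. Compound 2 `COc1cc(-c2nn(-c3cccc(NC(=O)Nc4ccc(Cl)c(Cl)c4)c3)cc2-c2ccncc2)ccc1Cl` has a 3,4-dichlorophenyl on the urea nitrogen. In this assay compound 2 gives > 50000 nM, also a limit. The step that the two limits leave unreadable from compound 1 to compound 3 and the step that the two limits leave unreadable from compound 2 to compound 3 cannot be sized; their ends are the limit of > 32500 nM in this assay, at which 1 of the 3 values shown sits, and (the limit of > 50000 nM in this assay, at which 2 of the 3 values shown sit). Compound 3 therefore stands where the other two values stand, at a limit, and nothing in these numbers separates it from compound 1 or compound 2.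

Compound 4 `COc1cc(-c2nn(-c3cccc(NC(=O)Nc4ccc(Cl)c(C(F)(F)F)c4)c3)cc2-c2ccncc2)ccc1Cl` differs from compound 3 by chloro in place of hydrogen on an aromatic carbon. Neither measured step gives a readable size that bears on this change, as all three values are limits. Compound 4 is expected to remain at a limit, so the expected step of a number no higher from compound 3 to compound 4 (the limit leaves the size open) is none beyond the scatter. For compound 4 the estimate in this assay is 50000 nM, with a range from 25000 nM to 100000 nM.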

Compound 4, concentration lethal to 50% of the cells: > 32500 nM
Compound 4 ended at the assay's limit (the forecaster's own chance of this, stated with the estimate: 85%); the middle value does not contradict the limit.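

In this assay compound 4 gives > 32500 nM, a limit of the assay, so its steps to compound 3 and compound 2 cannot be read: the limit of > 32500 nM in this assay, at which 2 of the 4 values shown sit.

The compounds shown leave open whether chloro in place of hydrogen, or trifluoromethyl in place of chloro, shifts the lethal concentration at all; none of the four values is a number.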